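A few compounds are considered here, and "the series" means these few. Any claim that something is new, unique, unknown or untested is made for them only; others in the source may bear on it.

Working notes on the series.

Compound 1 `COc1cc2c(Oc3ccc(NC(=O)c4cc(-c5ccc(C(F)(F)F)cc5)ccn4)cc3F)ccnc2cc1OCCCN1CCCCC1` carries a piperidin-1-yl group and in a functional assay on NCI-H460 cells (Homo sapiens) for cytotoxicity, read by MTT assay, with a stated time of 72 h (on this read-out lower numbers stand for stronger inhibition and higher numbers for weaker inhibition), compound 1 gives 360 nM. Compound 2 `COc1cc2c(Oc3ccc(NC(=O)c4cc(-c5ccc(C(F)(F)F)cc5)ccn4)cc3F)ccnc2cc1OCCCN1CCN(C)CC1` differs from compound 1 by 4-methylpiperazin-1-yl in place of piperidin-1-yl on a saturated chain carbon, three bonds along the chain from an oxygen on an aromatic ring, and in this assay compound 2 gives 160 nM; that change gave a 2.3-fold lower number from compound 1 to compound 2 (0.35 log units; beyond the scatter).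

Compound 3 `COc1cc2c(Oc3ccc(NC(=O)c4nccc(-c5ccc(C)cc5)n4)cc3F)ccnc2cc1OCCCN1CCCCC1` sits on a different core; the difference between the core of compound 3 and the core of compound 1 is not broken down here. In this assay compound 3 gives 230 nM, a number within the scatter of both compound 1 and compound 2.

Compound 4 `COc1cc2c(Oc3ccc(NC(=O)c4nccc(-c5ccc(C)cc5)n4)cc3F)ccnc2cc1OCCCN1CCN(C)CC1` has not yet been measured. It differs from compound 3 by 4-methylpiperazin-1-yl in place of piperidin-1-yl on a saturated chain carbon, three bonds along the chain from an oxygen on an aromatic ring, the same change as that from compound 1 to compound 2, at the same place word for word. Within the data shown here, only one measured instance of this change is available, so the expectation rests on that single step. For compound 4 the step expected in this assay is a 2.1-fold lower number from compound 3 to compound 4 (0.32 log units; beyond the scatter), set beside the measured one from compound 1 to compound 2 of a 2.3-fold lower number from compound 1 to compound 2 (0.35 log units; beyond the scatter). Compound 4 is accordingly estimated at 110 nM, with an expected range from 55 nM to 230 nM.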

Compound 4, half-maximal inhibitory concentration: 160 nM
The estimate for compound 4 lay 1.5-fold (0.16 log units) below the measured number, within the range that was stated.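

In this assay, 4-methylpiperazin-1-yl in place of piperidin-1-yl gives a 1.4-fold lower number from compound 3 to compound 4 (0.16 log units; within the scatter). The two measured instances of this change point the same way and do not differ beyond what repeated measurements allow: the same change on two cores in this assay, a 2.3-fold lower number (0.35 log units; beyond the scatter) from compound 1 to compound 2 and a 1.4-fold lower number (0.16 log units; within the scatter) from compound 3 to compound 4, 1.6-fold (0.19 log units) apart, within the scatter of two such steps. This makes the step on the core of compound 1 compatible with the step on the core of compound 3, but only the former lies beyond the scatter on its own, so two cores show neither that the change reliably lowers the number across the series nor how large the step is.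

The compounds shown leave open whether a morpholin-4-yl or dimethylamino group at the same place would fit with these two steps, and whether the step survives on a chain longer than the 3-(4-methylpiperazin-1-yl)propyl chain. They also leave open how the step behaves on cores that keep either the trifluoromethyl or the methyl group while changing only the rest of the core.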